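A third chloro on the aryl ether of compound 1

The source may hold more compounds than are shown below. What is called first, only, known or untested is meant among the compounds shown, and "the series" means these compounds.

Of the compounds shown here, three sharing one core have been tested in an ADME assay on MT4 cells (Homo sapiens) for cytotoxicity, read by MTT assay, with a stated time of 4 days; on this read-out higher numbers stand for lower toxicity in this test and lower numbers for higher toxicity in this test. Compound 1 `N#Cc1ccc(Nc2nc(Oc3ccc(Cl)cc3Cl)c3ccccc3n2)cc1` gives 32000 nM in this assay. Compound 2 `Cc1cc(Br)c(Oc2nc(Nc3ccc(C#N)cc3)nc3ccccc23)c(Br)c1` gives 25000 nM, and compound 3 `N#Cc1ccc(Nc2nc(Oc3ccc(Br)cc3)c3ccccc3n2)cc1` gives 215000 nM. Compound 1 thus stands second highest of the three numbers; its nearest neighbour is compound 2, with a 1.3-fold lower number from compound 1 to compound 2 (0.11 log units; within the scatter), while compound 3 lies furthest away, with a 6.7-fold higher number from compound 1 to compound 3 (0.83 log units; beyond the scatter).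

Compound 4 `N#Cc1ccc(Nc2nc(Oc3c(Cl)cc(Cl)cc3Cl)c3ccccc3n2)cc1` has not yet been measured. It differs from compound 1 in one place: chloro in place of hydrogen on an aromatic carbon.

Among the compounds with values here, the most telling measured step is the one from compound 1 to compound 2, where the dichlorophenyl was exchanged for a 2,6-dibromo-4-methylphenyl, so that both positions ortho to the large group carry a halogen, as they will in compound 4; that step, a 1.3-fold lower number from compound 1 to compound 2 (0.11 log units; within the scatter), stayed within the scatter. Within the data shown here, the step from compound 2 to compound 3, an 8.6-fold higher number from compound 2 to compound 3 (0.93 log units; beyond the scatter), shows that removing halogens from those positions moves the number upward, but no measured pair adds a single chloro at this spot. A small step is therefore expected for compound 4, a 1.1-fold lower number from compound 1 to compound 4 (0.06 log units; within the scatter), not beyond the scatter. Compound 4 is estimated at 28000 nM, with a range from 10000 nM to 80000 nM.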

Compound 4, half-maximal cytotoxic concentration: 56000 nM
Compound 4: middle estimate off by 2.0-fold (0.30 log units), on the low side; measured number inside the range.
By their numbers in this assay, from the lowest: compounds 2, 1 and 4 (each within the scatter of the next, the first and the last beyond it); then compound 3.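

In this assay, within the data shown here, the chloro that turns 2,4-dichlorophenyl into 2,4,6-trichlorophenyl is the first single-atom change seen at this place, ortho to a large group. That step is a 1.8-fold higher number from compound 1 to compound 4 (0.24 log units; within the scatter) and so stays within the usual scatter, which means that hydrogen and chloro at this carbon cannot be told apart on this read-out. The trichlorophenyl ether is nevertheless separated by more than the scatter from the two other aryl groups, with a 3.8-fold lower number from compound 3 to compound 4 (0.58 log units; beyond the scatter) and with a 2.2-fold higher number from compound 2 to compound 4 (0.35 log units; beyond the scatter), and nothing available explains these differences.

The aryl groups shown carry only chloro, bromo and methyl substituents, so it remains open whether an amine, a carboxylic acid or a longer chain such as propyl on this aromatic carbon would leave the number equally undisturbed. As far as these compounds go, it is also open whether this same chloro would give so small a step with other substituents on the ring, since the single-atom change is seen here only on the 2,4-dichlorophenyl group of compound 1.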